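This account rests on a few compounds, and the source may have more. Where it says the series, first, only, none or still open, it means among the compounds named here.

Compound 1, `CCOC(=O)C1(C(=O)Nc2ccc(F)cc2)CC1c1cc(OC)c(OC)c(OC)c1` — 63700 nM; > 100000 nM (2 entries)
Compound 2, `COc1cc([C@H]2C[C@@]2(CO)C(=O)Nc2ccccc2)cc(OC)c1OC` — > 100000 nM
Compound 3, `COc1cc([C@H]2C[C@@]2(CO)C(=O)NCc2ccc(C)cc2)cc(OC)c1OC` — > 100000 nM

In a functional assay on K562 cells (Homo sapiens) for cytotoxicity, read by MTT assay, with a stated time of 48 h (on this read-out lower numbers stand for stronger inhibition and higher numbers for weaker inhibition), compound 2 reaches only a limit of the assay, > 100000 nM. Compound 3 likewise reaches only a limit in this assay, > 100000 nM. The step that the two limits leave unreadable from compound 2 to compound 3 is therefore unreadable. Compound 1 gives 63700 nM; > 100000 nM (2 entries) in this assay, spread over several entries (the several entries of compound 1 in this assay, 63700 nM; > 100000 nM (2 entries)).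

Compound 4 is `COc1cc([C@@H]2C[C@@]2(CO)C(=O)Nc2ccccc2)cc(OC)c1OC`. It differs from compound 2 in that (the two compounds have the same atoms and bonds and differ only in configuration as drawn: 1 of 2 stereo elements differ; a stereocentre at a saturated ring carbon is drawn R in compound 2 and S in compound 4). No measured step concerns a change of configuration alone, and the single step available, from compound 2 to compound 3, cannot be read, so nothing shown points to a change beyond the scatter. Compound 4 is therefore expected to sit near the limit, estimated at 100000 nM with a range of 30000 nM to 300000 nM. The step of a number no higher from compound 2 to compound 4 (the limit leaves the size open) is thus expected to be none beyond the scatter.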

Compound 4, half-maximal inhibitory concentration: > 100000 nM
Compound 4 ended at the assay's limit (the forecaster's own chance of this, stated with the estimate: 70%); the middle value lies on the limit itself.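

Compound 2 and compound 4 both reach only a limit of the assay, so the step between them cannot be read. On these data alone, whether the configuration at that saturated ring carbon matters at all in this assay remains open.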